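The source may hold more compounds than are shown below. What is called first, only, known or untested is meant among the compounds shown, and "the series" means these compounds.

Working notes on the stilbene-derived series.

Three compounds have numbers in a functional assay on ileum (Cavia porcellus) for inhibition; on this read-out higher numbers stand for weaker inhibition and lower numbers for stronger inhibition. Compound 1 `Oc1cc(O)cc(CCc2ccc(O)c(O)c2)c1` gives 850 nM. Compound 2 `COc1cc(O)cc(CCc2ccc(O)cc2)c1` gives 140 nM. Compound 3 `COc1cccc(CCc2cc(O)cc(OC)c2)c1` gives 1280 nM, the highest number of the three. Its nearest neighbour by value is compound 1, and that gap lies within the scatter, so no order between compound 3 and compound 1 can be read. The gap to compound 2 lies beyond the scatter: compound 2 gives the lower number in this assay by a clear margin.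

Compound 4 `COc1cccc(CCc2cc(OC)cc(OC)c2)c1` has not yet been measured. It differs from compound 3 in one place: methyl in place of hydrogen on an oxygen on an aromatic ring. Among the measured compounds shown here, of the three measured compounds, the one carrying fewest methoxy groups and the one carrying most both sit at the high end, while compound 2 sits low, so the three values alone give no direction for this change. Compound 4 is expected to land near compound 3, with a step of a 1.6-fold higher number from compound 3 to compound 4 (0.19 log units; within the scatter) leaning toward a weaker inhibition. The estimate for compound 4 is 2000 nM, within 700 nM to 6000 nM.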

Compound 4, half-maximal inhibitory concentration: 960 nM
The estimate for compound 4 lay 2.1-fold (0.32 log units) above the measured number; the measured number falls inside the stated range.
By their numbers in this assay, from the lowest: compound 2; then compounds 1, 4 and 3 (each within the scatter of the next).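

In this assay, methyl in place of hydrogen on this oxygen gives a 1.3-fold lower number from compound 3 to compound 4 (0.12 log units; within the scatter), so hydroxy to methoxy at this place has no readable effect. Among the compounds shown here, this is the first pair that differs in one place, and it shows that the free hydroxy of compound 3 is not required to keep a number of this size when the rest of the structure stays the same. No data at hand bear on the reason for this outcome.

For the compounds shown here, whether the same change reads the same way on a compound carrying more hydroxy groups remains open, and no one-place step yet connects compound 2, at 140 nM, to the others. Also open, from the compounds shown here alone, is whether a longer chain on this oxygen, or an amine or a carboxylic acid at this place, would move the number beyond the scatter.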